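This account rests on a few compounds, and the source may have more. Where it says the series, first, only, none or still open, it means among the compounds named here.

Measured so far:
compound 1 `CCCCCCCC/C=C\CCCCCCC/C(S)=N/c1c(OC)cc(OC)cc1OC`: 900 nM
compound 2 `CCCCCCCCCCCCCCCCCCOC(=O)Nc1c(OC)cc(OC)cc1OC`: 7100 nM

In an assay on microsomes from intestinal mucosa for inhibition of acyl-CoA:cholesterol acyltransferase (Oryctolagus cuniculus) (on this read-out lower numbers stand for stronger inhibition and higher numbers for weaker inhibition), compound 2 gives 7100 nM, the higher of the two numbers at hand. Compound 1 gives 900 nM, a lower number, and the gap between the two lies beyond the usual scatter. The two compounds differ in more than one place. No single change is isolated by this pair.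

The next compound, compound 3 `CCCCCCCC/C=C\CCCCCCCCOC(=O)Nc1c(OC)cc(OC)cc1OC`, is not yet measured in this assay. Against compound 2 the change is dec-1-en-1-yl in place of decyl on a saturated chain carbon, eight bonds along the chain from an oxygen next to a carbonyl group. Among the compounds with values here, no measured pair isolates this change. Compound 1 also carries an unsaturated chain and gives the lower number, but its other differences from compound 2 keep it from being a clean guide. A modest step downward is expected, a 2.0-fold lower number from compound 2 to compound 3 (0.31 log units; beyond the scatter), not far beyond the scatter. For compound 3 the estimate in this assay is 3500 nM, within 1200 nM to 9000 nM.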

Compound 3, half-maximal inhibitory concentration: 860 nM
The estimate for compound 3 lay 4.1-fold (0.61 log units) above the measured number; measured number outside the range, below it.
By their numbers in this assay, from the lowest: compounds 3 and 1 (each within the scatter of the next); then compound 2.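

In this assay, dec-1-en-1-yl in place of decyl, on a saturated chain carbon eight bonds along the chain from an oxygen next to a carbonyl group, gives an 8.3-fold lower number from compound 2 to compound 3 (0.92 log units; beyond the scatter), the first single change isolated in this series. Both groups hold 10 carbon atoms and neither has a ring, so the step, which lies beyond the scatter, comes with one double bond outside aromatic rings as the counted difference. Nothing at hand gives a reason for this step.

The compounds shown leave open whether a dec-1-yn-1-yl group, with a triple bond in the same place, would give a number like that of compound 3. They also leave open whether a shorter or a longer chain carrying the double bond would keep the step.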